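Swapping Ethoxy for Cyano on the Aryl Ring

The source may hold more compounds than are shown below. What is called first, only, known or untested is meant among the compounds shown, and "the series" means these compounds.

Of the compounds shown here, three built on one shared core have been measured in an assay on cells for inhibition of Palmitoleoyl-protein carboxylesterase NOTUM variant C330S (Homo sapiens), read by fluorescence, with a stated time of 40 min; a lower number here means a stronger inhibitor, a higher number a weaker inhibitor. Compound 1 `Cc1cc(C(=O)O)c(C)n1-c1cccc(C#N)c1F` gives 630 nM. Compound 2 `Cc1cc(C(=O)O)c(C)n1-c1cccc(C2CC2)c1` gives 580 nM. Compound 3 `CCOc1cccc(-n2c(C)cc(C(=O)O)c2C)c1` gives 640 nM. The number for compound 3 sits alongside those of compound 1 and compound 2, all three within the usual scatter of one another, so no real difference among them can be claimed. For the measured compounds named here, the one step that connects two of them, a 1.1-fold higher number from compound 2 to compound 3 (0.04 log units; within the scatter), shows that exchanging one group at this position for another left the number essentially where it was.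

Compound 4 `Cc1cc(C(=O)O)c(C)n1-c1cccc(C#N)c1` differs from compound 3 by cyano in place of ethoxy on an aromatic carbon. Going by the values given here, the step from compound 2 to compound 3 is the only measured step at this position, and it was flat, so a change beyond the scatter is not expected here either. Compound 1, which also carries a cyano, gives 630 nM, pointing the same way. Compound 4 is therefore estimated at 600 nM, with a likely range from 300 nM to 1200 nM. The expected step is a 1.1-fold lower number from compound 3 to compound 4 (0.03 log units; within the scatter), within the scatter.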

Compound 4, half-maximal inhibitory concentration: 3100 nM
Compound 4: middle estimate off by 5.2-fold (0.71 log units), on the low side; measured number outside the range, above it.
By their numbers in this assay, from the lowest: compounds 2, 1 and 3 (each within the scatter of the next); then compound 4.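

In this assay, this position does respond to the group it carries: cyano in place of ethoxy gives a 4.8-fold higher number from compound 3 to compound 4 (0.69 log units; beyond the scatter) and cyano in place of cyclopropyl gives a 5.3-fold higher number from compound 2 to compound 4 (0.73 log units; beyond the scatter) so the flat step between ethoxy and cyclopropyl does not hold for every group here. Cyano alone does not settle the number, since hydrogen in place of fluoro gives a 4.9-fold higher number from compound 1 to compound 4 (0.69 log units; beyond the scatter) and this pair differs only in that one place. Nothing available here offers a reason for the size of these steps.

From the compounds shown here alone, whether a longer chain such as propoxy or a group such as an amine would stay with ethoxy or fall with cyano remains open. So does whether adding fluoro to the ethoxy or cyclopropyl compounds would change their numbers as it does for the cyano pair.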